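A few compounds are considered here, and "the series" means these few. Any claim that something is new, unique, unknown or untested is made for them only; others in the source may bear on it.

Three compounds share a core in which a five-membered non-aromatic ring with one nitrogen and one oxygen carries an aryl group on a carbon with a double bond to nitrogen. Compound 1 `COc1cc(-n2nnnc2-c2ccc(OCC3CC(c4cccc(Cl)c4)=NO3)c(N)c2)cc(OC)c1OC` bears a 3-chlorophenyl there; in a functional assay on MDA-MB-231 cells (Homo sapiens) for cytotoxicity, read by MTT assay, with a stated time of 48 h (a lower number here means a stronger inhibitor, a higher number a weaker inhibitor), compound 1 gives 2180 nM. Compound 2 `COc1cc(C2=NOC(COc3ccc(-c4nnnn4-c4cc(OC)c(OC)c(OC)c4)cc3N)C2)cc(OC)c1OC` bears a 3,4,5-trimethoxyphenyl and in this assay compound 2 gives 3230 nM. Compound 3 `COc1ccc(C2=NOC(COc3ccc(-c4nnnn4-c4cc(OC)c(OC)c(OC)c4)cc3N)C2)cc1N` bears a 3-amino-4-methoxyphenyl and in this assay compound 3 gives 3000 nM. Compound 2 lies within the scatter of both others: a 1.5-fold higher number from compound 1 to compound 2 (0.17 log units; within the scatter), a 1.1-fold lower number from compound 2 to compound 3 (0.03 log units; within the scatter), and likewise a 1.4-fold higher number from compound 1 to compound 3 (0.14 log units; within the scatter). Swapping the aryl group at this position has so far moved nothing beyond the scatter.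

Compound 4 `COc1cc(-n2nnnc2-c2ccc(OCC3CC(c4ccc(OC)c(OC)c4OC)=NO3)c(N)c2)cc(OC)c1OC` differs from compound 2 by 2,3,4-trimethoxyphenyl in place of 3,4,5-trimethoxyphenyl on a carbon with a double bond to nitrogen. Since every measured swap at this carbon stayed within the scatter, no step beyond the scatter is expected here either: compound 4 is expected to give 3000 nM, with a likely range of 1500 nM to 6500 nM, which means an expected step of a 1.1-fold lower number from compound 2 to compound 4 (0.03 log units; within the scatter).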

Compound 4, half-maximal inhibitory concentration: 3540 nM
Compound 4: middle estimate off by 1.2-fold (0.07 log units), on the low side; low and high end bracket the measured number.
By their numbers in this assay, from the lowest: compounds 1, 3, 2 and 4 (each within the scatter of the next).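

Rearranging the three methoxy groups on the aryl ring, with the same atoms joined differently, leaves the number in this assay within the scatter (a 1.1-fold higher number from compound 2 to compound 4 (0.04 log units; within the scatter)). The new compound also stays within the scatter of the two other aryl groups (a 1.2-fold higher number from compound 3 to compound 4 (0.07 log units; within the scatter); a 1.6-fold higher number from compound 1 to compound 4 (0.21 log units; within the scatter)), so the four compounds cannot be told apart here, even with two different arrangements of the same three methoxy groups at this carbon. No other measurement offers an explanation for this flat result.

Going by these compounds, whether a group other than a substituted phenyl at this carbon, such as a methyl, a carboxylic acid or a piperidine, would move the number beyond the scatter remains open. All four compounds keep the rest of the shared core, so the effect of a change elsewhere is open too.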